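Three limits and a chloro analogue in one series

This account rests on a few compounds, and the source may have more. Where it says the series, first, only, none or still open, it means among the compounds named here.

Measured compounds:
compound 1 `C=C[C@@](C)(/C=C/c1ccc(O)cc1)CC/C=C(C)/C=N/N`: > 26000 nM
compound 2 `COc1ccc(/C=C/[C@@](C)(/C=C/c2ccc(O)cc2)CCC=C(C)C)cc1`: > 26000 nM
compound 3 `C=C[C@@](C)(/C=C/c1ccc(Nc2ccc(OC)cc2)cc1)CCC=C(C)C`: > 26000 nM

In a functional assay on Raji cells (Homo sapiens) for cytotoxicity, with a stated time of 72 h (on this read-out higher numbers stand for an effect only at larger amounts of compound and lower numbers for an effect already at smaller amounts), compound 1 gives > 26000 nM, which is a limit of the assay and not a number. Compound 2 likewise gives > 26000 nM in this assay, again a limit. Compound 3 gives > 26000 nM in this assay, also a limit. For the measured compounds named here, compound 3 therefore stands where every measured member of the series stands, at the limit of > 26000 nM in this assay, at which 3 of the 3 values shown sit; no value shown is a number, and no step between measured compounds can be sized.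

Compound 4 `C=C[C@@](C)(/C=C/c1ccc(Nc2ccc(Cl)cc2)cc1)CCC=C(C)C` differs from compound 3 in one place: chloro in place of methoxy on an aromatic carbon. The methoxy group leaves, the chloro group enters, on an aromatic carbon of a six-membered aromatic ring of carbon only, para to a large group.

Going by the values given here, with all three measured values sitting at the limit, there is no measured step on which to rest a direction. The step from compound 3 to compound 4 is expected to be none beyond the scatter, a number no higher from compound 3 to compound 4 (the limit leaves the size open), with the change most likely leaving compound 4 at the same limit. Compound 4 is estimated at 26000 nM in this assay, with a range of 9000 nM to 80000 nM, and the assay is expected most often to report only a limit for it.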

Compound 4, half-maximal effective concentration: > 26000 nM
Compound 4 gave a limit, no number (the forecaster's own chance of this, stated with the estimate: 75%); the middle value lies on the limit itself.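

Compound 4, with chloro in place of the methoxy of compound 3, gives only a limit in this assay, as compound 3 does, so no step can be read between compound 3 and compound 4: the limit of > 26000 nM in this assay, at which 4 of the 4 values shown sit.

The compounds shown leave open how any member of the series ranks against another, and which change to the shared core, if any, would give a number rather than a limit in this assay.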